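This account rests on a few compounds, and the source may have more. Where it says the series, first, only, none or still open, it means among the compounds named here.

Measured so far in a functional assay on the whole organism for inhibition, with Rattus norvegicus as the target, read by paw edema, at a dose of 100 mg/kg by the oral route; a lower number here means less inhibition, a higher number more inhibition at the dose given (going by the name of the read-out):
compound 1 `COc1ccc(NC(=O)c2c(O)c3cccnc3n(-c3ccccc3)c2=O)cc1`: 0.3%
compound 2 `O=C(Nc1cccc([N+](=O)[O-])c1)c1c(O)c2cccnc2n(-c2ccccc2)c1=O`: 5.7%

Both compounds share one core and differ only in the aryl group carried on the amide-type nitrogen. Among the compounds with values here, compound 2 stands beside compound 1 in this assay, the two numbers lying inside the usual scatter of each other, so nothing separates them; the one measured step, a number 5.4 percentage points higher from compound 1 to compound 2 (within the scatter), is the only guide to how this position behaves.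

Compound 3 `O=C(Nc1cccnc1)c1c(O)c2cccnc2n(-c2ccccc2)c1=O` is the next compound to be measured. The change from compound 2 is pyridin-3-yl in place of 3-nitrophenyl on an amide-type nitrogen.

The step from compound 1 to compound 2 bears directly on this, since it also swapped the aryl group on the same amide-type nitrogen, and it did not move the number beyond the scatter. On that basis the step to compound 3 is expected to be a number 1.7 percentage points lower from compound 2 to compound 3 (within the scatter), which is no change beyond the scatter. Compound 3 is therefore estimated to give 4% in this assay, in a range from 0% to 15%.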

Compound 3, a percentage reported as inhibition, in the whole organism at one dose (the size of the read-out at that dose, not a potency): 30.3%
Compound 3: middle estimate off by 26.3 percentage points, on the low side; measured number above the stated range.
By their numbers in this assay, from the lowest: compounds 1 and 2 (each within the scatter of the next); then compound 3.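

In this assay the aryl group on the amide-type nitrogen turns out to matter: pyridin-3-yl in place of 3-nitrophenyl gives a number 24.6 percentage points higher from compound 2 to compound 3 (beyond the scatter) and pyridin-3-yl in place of 4-methoxyphenyl gives a number 30 percentage points higher from compound 1 to compound 3 (beyond the scatter) in the same direction. Compound 1 and compound 2 both carry an aromatic ring of carbon only and could not be told apart, whereas compound 3, with one hetero atom in that ring and no further group on it, stands clear of both, so this position can respond to a change of aryl group. No measurement at hand explains the rise.

Within the data shown here, with only one ring of this kind, the data cannot separate the effect of the ring nitrogen from the loss of the nitro or methoxy group, and plain phenyl, which has neither, would be the direct comparison. Pyridin-2-yl and pyridin-4-yl would show whether the place of the ring nitrogen counts, while each number remains a reading at a single dose rather than a potency.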